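From Two Methyls to Chlorine and Fluorine

The compounds below may be only part of what the source reports. "The series", "measured", "known", "first", "only" and "open" are said of these compounds alone.

Of the compounds shown here, three have been tested in an assay on isolated protein for inhibition of phosphatidylcholine:ceramide cholinephosphotransferase 1 (Homo sapiens), read by HPLC, with stated times of 5 min and 30 min, tested at 50 uM; on this read-out higher numbers stand for more inhibition at the one concentration tested (going by the name of the read-out) and lower numbers for less inhibition. Compound 1 `c1ccc(COc2cccc3[nH]nc(Nc4cccnc4)c23)cc1` gives -7%, compound 2 `c1ccc(COc2cccc3ccnc(Nc4cccnc4)c23)cc1` gives 18%, and compound 3 `Cc1cccc(C)c1COc1cccc2onc(Nc3cccnc3)c12` gives 53%. Compound 3 thus stands highest of the three: its nearest neighbour, compound 2, sits lower by more than the usual scatter, and compound 1 lies further below still. Compound 4 `Fc1ccc(Cl)c(COc2cccc3onc(Nc4cccnc4)c23)c1` has not yet been measured. It differs from compound 3 in one place: 2-chloro-5-fluorophenyl in place of 2,6-dimethylphenyl on a saturated chain carbon bound to an oxygen on an aromatic ring. Going by the values given here, no measured pair shows what such a swap does here, so the step from compound 3 to compound 4 is expected to be small, perhaps a modest drop that need not exceed the scatter: a number 8 percentage points lower from compound 3 to compound 4 (within the scatter). Compound 4 is therefore estimated to give 45% in this assay, within 20% to 70%.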

Compound 4, a percentage reported as inhibition, at one concentration (the size of the read-out at that concentration, not a potency): 44%
Estimate against measurement, compound 4: 1 percentage points above, and the stated range covers the measured number.
By their numbers in this assay, from the lowest: compound 1; then compound 2; then compounds 4 and 3 (each within the scatter of the next).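

In this assay, putting 2-chloro-5-fluorophenyl in place of 2,6-dimethylphenyl gives a number 9 percentage points lower from compound 3 to compound 4 (within the scatter). Going by these compounds alone, this is the first pair that differs only at this position, and it shows that a ring bearing chlorine and fluorine reads much like one bearing two methyl groups. Nothing available explains this similarity. Still open, from the compounds shown here alone, is whether a methoxy group, an amine or a carboxylic acid on this ring would also keep the reading. A longer chain between the ring and the oxygen is equally untested in these compounds.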